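A few compounds are considered here, and "the series" means these few. Any claim that something is new, unique, unknown or untested is made for them only; others in the source may bear on it.

Compound 3 `Cc1cccc(-n2cc(COc3ccc4c(c3)CCC4)nn2)c1` gives 23.4% in an ADME assay on HEK293 cells (Homo sapiens) for inhibition, read by MTT assay, with a stated time of 48 h, tested at 25 uM; on this read-out lower numbers stand for less inhibition and higher numbers for more inhibition at the one concentration tested (going by the name of the read-out). Compound 2 `c1ccc(-n2cc(COc3ccc4c(c3)CCC4)nn2)cc1` gives 23.4%, and the step of no change at the digits printed from compound 2 to compound 3 (within the scatter) lies within the scatter. Compound 1 `COc1ccccc1-n1cc(COc2ccc3c(c2)CCC3)nn1` gives 19.8%, and the step of a number 3.6 percentage points higher from compound 1 to compound 3 (within the scatter) likewise stays within the scatter, so the three measured numbers sit together and no one of them can be called stronger than another. Compound 4 `Fc1ccccc1-n1cc(COc2ccc3c(c2)CCC3)nn1` differs from compound 3 by 2-fluorophenyl in place of 3-methylphenyl on an aromatic nitrogen. Going by the values given here, the steps that bear on this change are the aryl swap a number 3.6 percentage points higher from compound 1 to compound 3 (within the scatter) and the removal of the methoxy group a number 3.6 percentage points higher from compound 1 to compound 2 (within the scatter), both within the scatter. Compound 4 is therefore expected to show a step of a number 1.4 percentage points lower from compound 3 to compound 4 (within the scatter), no more than the scatter, and its estimated value is 22%, within 12% to 32%.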

Compound 4, a percentage reported as inhibition, at one concentration (the size of the read-out at that concentration, not a potency): 21%
For compound 4 the middle estimate is 1 percentage points above the measured one; the measured number falls inside the stated range.
By their numbers in this assay, from the lowest: compounds 1, 4, 2 and 3 (each within the scatter of the next).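

In this assay fluoro on the aryl group on the aromatic nitrogen leaves the read-out flat: fluoro in place of hydrogen gives a number 2.4 percentage points lower from compound 2 to compound 4 (within the scatter) and fluoro in place of methoxy gives a number 1.2 percentage points higher from compound 1 to compound 4 (within the scatter), while 2-fluorophenyl in place of 3-methylphenyl gives a number 2.4 percentage points lower from compound 3 to compound 4 (within the scatter). A halogen therefore joins methoxy and methyl among the groups here that do not separate from the unsubstituted aryl group. Nothing measured offers a reason for this. As far as these compounds go, it remains open whether an amine or a carboxylic acid on this aryl group would move the read-out beyond the scatter.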